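The source may hold more compounds than are shown below. What is called first, only, known or untested is meant among the compounds shown, and "the series" means these compounds.

Three compounds share a core in which a piperidine-like saturated nitrogen ring is linked through an oxygen to a cyclohexane, which in turn carries an aromatic ring through a second oxygen. Compound 1 `CC(C)(C)OC(=O)N1CCC(O[C@H]2CC[C@H](Oc3ccc(C#N)cc3)CC2)CC1` gives 116% in a functional assay on isolated protein for agonist activity at Glucose-dependent insulinotropic receptor (Homo sapiens), read by HTRF and cAMP accumulation; on this read-out lower numbers stand for smaller maximal responses and higher numbers for larger maximal responses. Compound 2 `CC(C)(C)OC(=O)N1CCC(O[C@H]2CC[C@H](Oc3ccc(S(C)(=O)=O)cn3)CC2)CC1` gives 111% in this assay, and the step of a number 5 percentage points lower from compound 1 to compound 2 (within the scatter) lies within the scatter. Compound 3 `CS(=O)(=O)c1cnc(O[C@H]2CC[C@H](OC3CCN(C(=O)OC4CCOC4)CC3)CC2)cn1` gives 105%, the smallest of the three numbers; its gap to compound 2 lies within the scatter, while only the gap to compound 1 lies beyond it. Compound 2 and compound 3 differ in two places, so their two values alone are what they show.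

Compound 4 `CC(F)Cc1nc(CN2CCC(O[C@H]3CC[C@H](Oc4cnc(S(C)(=O)=O)cn4)CC3)CC2)no1` differs from compound 3 in one place: (5-(2-fluoropropyl)-1,2,4-oxadiazol-3-yl)methyl in place of ((oxolan-3-yl)oxy)carbonyl on an amine nitrogen in a ring. Among the measured compounds shown here, the only measured step changes the aromatic ring on the oxygen of the saturated carbon, not the group on the amine nitrogen in the ring, so no measured step bears directly on this change. All three measured maximal responses sit close together, and compound 4 is expected to stay in that range, with a step of no change at the digits printed from compound 3 to compound 4 (within the scatter) not beyond the scatter. Compound 4 is therefore estimated at 105%, within 88% to 122%.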

Compound 4, largest response reached (Emax), in percent of the reference or control that the assay uses: 97%
The estimate for compound 4 lay 8 percentage points above the measured number; the measured number falls inside the stated range.
By their numbers in this assay, from the lowest: compounds 4, 3, 2 and 1 (each within the scatter of the next, the first and the last beyond it).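

Among the compounds shown here, this is the first single change at the amine nitrogen in a ring, the position that carried only carbonyl-linked groups in compounds 1 to 3. In this assay, putting (5-(2-fluoropropyl)-1,2,4-oxadiazol-3-yl)methyl in place of ((oxolan-3-yl)oxy)carbonyl gives a number 8 percentage points lower from compound 3 to compound 4 (within the scatter), so this position accepts a group with a five-membered aromatic ring and no double bond outside aromatic rings without a step beyond the scatter, even though the two groups have the same counts of hydrogen-bond donors and acceptors and differ in their rings and atoms. No measurement offered here explains why the maximal response holds across this exchange.

On these data alone, a single step cannot separate the parts of the entering group, so it remains open whether the fluorine, the 1,2,4-oxadiazole ring or the methyl link matters, and whether a plain propyl chain or a phenyl ring in place of the 2-fluoropropyl would fit as well. As far as these compounds go, it also remains open how a ring nitrogen bearing only hydrogen or a carboxylic acid on the link would behave, and a maximal response says nothing about the concentration needed to reach it.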